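Thiophen-2-yl in place of (pyrrolidin-1-yl)carbonyl: half-life notes

The compounds below may be only part of what the source reports. "The series", "measured", "known", "first", "only" and "open" are said of these compounds alone.

Two compounds of the series have numbers in an ADME assay (Rattus norvegicus, strain Han-wistar) for metabolic stability, at a dose of 1.5 umol/kg by the intravenous route; a higher number here means that the compound lasts longer, a lower number that the compound disappears faster. There, compound 1 `CNC(=O)CN1CCC(c2cc3c(-c4ccc(=O)n(C(C)C)c4)ccnc3[nH]2)CC1` gives 0.7 h and compound 2 `CC(C)n1cc(-c2ccnc3[nH]c(C4CCN(CC(=O)N5CCCC5)CC4)cc23)ccc1=O` gives 1.1 h. These two values lie within the scatter of each other, so compound 2 stands level with compound 1 on the present numbers.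

Compound 3 `CC(C)n1cc(-c2ccnc3[nH]c(C4CCN(Cc5cccs5)CC4)cc23)ccc1=O` keeps the shared core and differs from compound 2 in one place: thiophen-2-yl in place of (pyrrolidin-1-yl)carbonyl on a saturated chain carbon bound to an amine nitrogen in a ring. Among the compounds with values here, only one measured step bears on this change, and only loosely: a 1.6-fold higher number from compound 1 to compound 2 (0.20 log units; within the scatter). Within the data shown here, that step alters the group on the carbonyl carbon, whereas here the carbonyl itself leaves, and no measured pair covers such a loss. The data therefore give no direction for the change. Among the measured compounds shown here, with a 1.6-fold higher number from compound 1 to compound 2 (0.20 log units; within the scatter) as the only guide, no step beyond the scatter is expected in this assay. The estimated step is a 1.1-fold lower number from compound 2 to compound 3 (0.04 log units; within the scatter), which amounts to no expected change. For compound 3 the expected half-life is 1 h, with an estimated range of 0.5 h to 2.2 h.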

Compound 3, half-life: 0.4 h
Compound 3: middle estimate off by 2.5-fold (0.40 log units), on the high side; measured number below the stated range.
By their numbers in this assay, from the lowest: compounds 3, 1 and 2 (each within the scatter of the next, the first and the last beyond it).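

In this assay this position now shows a step beyond the scatter: replacing (pyrrolidin-1-yl)carbonyl with thiophen-2-yl on a saturated chain carbon bound to an amine nitrogen in a ring gives a 2.8-fold lower number from compound 2 to compound 3 (0.44 log units; beyond the scatter) in this series. The corresponding change from methylcarbamoyl gives a 1.8-fold lower number from compound 1 to compound 3 (0.24 log units; within the scatter) and stays within the scatter, so the thiophen-2-yl group is separated only from the pyrrolidin-1-yl amide and the result depends on which amide serves as the reference. No measurement on hand accounts for the difference between these two readings.

The change from compound 2 to compound 3 removes the carbonyl and brings in the thiophen-2-yl ring at once, so the compounds shown cannot assign the step to either part. Going by these compounds, a phenyl ring, a carboxylic acid or a longer chain at the same place remains open, and any of these would show whether the lower half-life of compound 3 belongs to the thiophen-2-yl group alone or extends to other replacements of the amide.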